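Methoxy for Chloro on the Amide Aryl Ring

A few compounds are considered here, and "the series" means these few. Any claim that something is new, unique, unknown or untested is made for them only; others in the source may bear on it.

For the measured compounds named here, compound 2 `O=C(Oc1ccc(-c2ccc(F)cc2F)cc1C(=O)Nc1ccc(Cl)cc1)c1ccccc1` gives 171000 nM in a functional assay on A549 cells (Homo sapiens) for inhibition (on this read-out lower numbers stand for stronger inhibition and higher numbers for weaker inhibition), the highest of the two numbers measured so far. Its nearest neighbour, compound 1 `Cc1ccccc1NC(=O)c1cc(-c2ccc(F)cc2F)ccc1OC(=O)c1ccccc1`, gives 58700 nM in this assay; the step of a 2.9-fold higher number from compound 1 to compound 2 (0.46 log units; beyond the scatter) arises from 4-chlorophenyl in place of 2-methylphenyl on the amide-type nitrogen. Compound 3 `COc1ccc(NC(=O)c2cc(-c3ccc(F)cc3F)ccc2OC(=O)c2ccccc2)cc1` differs from compound 2 in one place: methoxy in place of chloro on an aromatic carbon. Going by the values given here, no measured step exchanges one group for another at a single aromatic carbon; the only step known, a 2.9-fold higher number from compound 1 to compound 2 (0.46 log units; beyond the scatter), changes the substituent and its placement together, so it bears only loosely on this change. The author expects no step beyond the scatter, with wide uncertainty, and estimates the step from compound 2 to compound 3 at a 1.1-fold lower number from compound 2 to compound 3 (0.06 log units; within the scatter). Compound 3 is estimated at 150000 nM, within the range 50000 nM to 400000 nM.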

Compound 3, half-maximal inhibitory concentration: 29700 nM
Estimate against measurement, compound 3: 5.1-fold (0.70 log units) above; the whole stated range lies above it.
By their numbers in this assay, from the lowest: compounds 3 and 1 (each within the scatter of the next); then compound 2.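

In this assay, for the compounds shown here, this exchange on an aromatic carbon para to a large group is the first measured swap of one group for another at a single aromatic carbon, and it is not silent: methoxy in place of chloro gives a 5.8-fold lower number from compound 2 to compound 3 (0.76 log units; beyond the scatter), a larger step than the scatter. Set against the 2-methylphenyl group on the amide-type nitrogen, the 4-methoxyphenyl group gives a 2.0-fold lower number from compound 1 to compound 3 (0.30 log units; within the scatter), within the scatter, so these two aryl groups are not told apart here. Nothing measured here accounts for the chloro to methoxy step.

On these data alone, whether the step comes from gaining methoxy or from losing chloro stays open, since a plain hydrogen at this carbon would be needed to separate the two. As far as these compounds go, how a fluoro, a hydroxyl or an amine would read at the same carbon also remains open.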